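Extending the Ketone Side Chain of a Caspase-8 Inhibitor

This account rests on a few compounds, and the source may have more. Where it says the series, first, only, none or still open, it means among the compounds named here.

Of the compounds shown here, three sharing one core have been tested in an assay for inhibition of Caspase-8 (Homo sapiens); a higher number here means a weaker inhibitor, a lower number a stronger inhibitor. Compound 1 `CCC(C(=O)N[C@@H](CC(=O)O)C(C)=O)n1cc(C(C)(C)C)nc(NCc2nonc2C)c1=O` gives 10000 nM, and compound 3 `CCC(C(=O)N[C@@H](CC(=O)O)C(=O)CSCc1ccccc1)n1ccnc(NCc2cncs2)c1=O` gives 6590 nM, so these two numbers lie within the usual scatter of each other. For compound 2 `CCCCCCN(C)CNCC(=O)[C@H](CC(=O)O)NC(=O)C(CC)n1ccnc(NCc2nonc2C)c1=O` the method reports only a limit, > 10000 nM, as described in the limit of > 10000 nM in this assay, at which 1 of the 3 values shown sits. Compound 4 `CCC(C(=O)N[C@@H](CC(=O)O)C(=O)CNCN1CCCCC1)n1cc(C(C)(C)C)nc(NCc2nonc2C)c1=O` differs from compound 1 in one place: ((piperidin-1-yl)methyl)amino in place of hydrogen on a saturated chain carbon bound to a carbonyl carbon. Compound 2 carries a related chain in that place and gave only the limit of > 10000 nM. No gain is therefore expected from this change. The step is estimated as no change at the digits printed from compound 1 to compound 4 (within the scatter), nothing beyond the scatter. Compound 4 is expected to give about 10000 nM, between 4000 nM and 25000 nM.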

Compound 4, half-maximal inhibitory concentration: > 10000 nM
Compound 4: no number, only a limit; the forecaster's own chance of this, stated with the estimate: 50%; the middle value sits exactly at the limit.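

In this assay, putting ((piperidin-1-yl)methyl)amino in place of hydrogen on the saturated chain carbon bound to a carbonyl carbon gives a number no lower from compound 1 to compound 4 (the limit leaves the size open). Compound 4 gives only a limit, so this first one-place comparison at this position shows no gain from this group, while the size of the step cannot be read. That limit now recurs among the compounds shown: the limit of > 10000 nM in this assay, at which 2 of the 4 values shown sit.

As far as these compounds go, whether a much smaller group on this carbon, such as a hydroxyl group or a single fluorine atom, would lower the number stays open. So does whether any group in this place can give a stronger inhibitor.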